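Trimming the Amine Chain of Compound 3

The source may report more compounds than this note shows. Statements on the series, on what has been measured and on what is new or still open speak of the compounds shown alone.

Of the compounds shown here, three sharing one core have been tested in a functional assay on MCF7 cells (Homo sapiens), read by MTT assay, with a stated time of 48 h; a lower number here means a stronger inhibitor, a higher number a weaker inhibitor. Compound 1 `CCOC(=O)CN(C)C(=O)c1ccc(C(CC)(CC)c2ccc(OCC(O)C(C)(C)C)c(C)c2)n1CC` gives 9200 nM, compound 2 `CCn1c(C(=O)NCCCN(C)C)ccc1C(CC)(CC)c1ccc(OCC(O)C(C)(C)C)c(C)c1` gives 490 nM, and compound 3 `CCN(CC)CCCNC(=O)c1ccc(C(CC)(CC)c2ccc(OCC(O)C(C)(C)C)c(C)c2)n1CC` gives 190 nM, the lowest number of the three. Compound 4 `CCn1c(C(=O)NCCN)ccc1C(CC)(CC)c1ccc(OCC(O)C(C)(C)C)c(C)c1` is still unmeasured. It differs from compound 3 by having amino in place of (diethylamino)methyl on a saturated chain carbon, two bonds along the chain from an amide-type nitrogen.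

The closest guide is a 2.6-fold lower number from compound 2 to compound 3 (0.41 log units; beyond the scatter), a modest step that came with diethylamino replacing dimethylamino. The large steps, a 19-fold lower number from compound 1 to compound 2 (1.27 log units; beyond the scatter) and a 48-fold lower number from compound 1 to compound 3 (1.69 log units; beyond the scatter), replace the whole ((ethoxycarbonyl)methyl)(methyl)amino group, so they say less about this change. Among the measured compounds shown here, no tested compound has a shorter chain or a bare amino end, which leaves the forecast uncertain. Given a 2.6-fold lower number from compound 2 to compound 3 (0.41 log units; beyond the scatter), a modest rise in the number is expected, a 3.7-fold higher number from compound 3 to compound 4 (0.57 log units; beyond the scatter). Compound 4 is estimated at 700 nM, with an expected range of 200 nM to 2500 nM.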

Compound 4, half-maximal inhibitory concentration: 5.9 nM
Beside the measured number, compound 4's estimate is 120-fold (2.07 log units) above it, and the stated range ends above it.
By their numbers in this assay, from the lowest: compound 4; then compound 3; then compound 2; then compound 1.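

In this assay, among the compounds shown here, the change to amino from (diethylamino)methyl gives a 32-fold lower number from compound 3 to compound 4 (1.51 log units; beyond the scatter) and the change from (dimethylamino)methyl gives an 83-fold lower number from compound 2 to compound 4 (1.92 log units; beyond the scatter) on this saturated chain carbon, so this position can move the number far more than the earlier compounds showed. The earlier step from dimethylamino to diethylamino, a 2.6-fold lower number from compound 2 to compound 3 (0.41 log units; beyond the scatter) on its own, pointed toward larger groups on the end nitrogen, and compound 4 goes against that reading with the lowest number of the set. Replacing the ((ethoxycarbonyl)methyl)(methyl)amino group with (2-aminoethyl)amino gives a 1600-fold lower number from compound 1 to compound 4 (3.19 log units; beyond the scatter) as the widest step in the series.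

Nothing among the data offers a reason for this result. The change also shortens the chain, so telling chain length apart from the bare amino end would take a 3-aminopropyl chain or a 2-(diethylamino)ethyl chain.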